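The source may hold more compounds than are shown below. What is called first, only, known or untested is meant among the compounds shown, and "the series" means these compounds.

In a functional assay on the whole organism (strain Swiss albino) for inhibition, with Mus musculus as the target, with stated times of 10 min, 5 min and 20 min, at a dose of 2.5 mg/kg by the intraperitoneal route (on this read-out higher numbers stand for an effect only at larger amounts of compound and lower numbers for an effect already at smaller amounts), compound 1 `COc1ccccc1N1CCN(CCCOc2ccccc2C(N)=O)CC1` gives 50 mg/kg. Compound 2 `NC(=O)c1ccccc1OCCCCN1CCN(c2ccccc2)CC1` gives only a limit of the assay, > 40 mg/kg, so where it sits on the numbers is not known. Compound 2 thus stands at the limit of > 40 mg/kg in this assay, at which 1 of the 2 values shown sits. Compound 3 `COc1ccccc1N1CCN(CCCCOc2ccccc2C(N)=O)CC1` differs from compound 2 by methoxy in place of hydrogen on an aromatic carbon. Among the compounds with values here, no measured pair shows this change, so the step expected in this assay, a step that the limit leaves unreadable from compound 2 to compound 3, is small and in neither direction beyond the usual scatter. On that basis compound 3 is expected to give around 45 mg/kg, within a range from 20 mg/kg to 100 mg/kg.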

Compound 3, dose for half-maximal effect: 50.8 mg/kg
Compound 3: middle estimate off by 1.1-fold (0.05 log units), on the low side; low and high end bracket the measured number.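

No step can be read from compound 2 to compound 3, since compound 2 is recorded only as a limit: the limit of > 40 mg/kg in this assay, at which 1 of the 3 values shown sits.

The compounds shown leave open how far methoxy in place of hydrogen on an aromatic carbon moves the value in this assay.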